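A few compounds are considered here, and "the series" means these few. Any claim that something is new, unique, unknown or untested is made for them only; others in the source may bear on it.

Series notes, step from compound 2 to compound 3.

Two members of this series have numbers in an in vitro functional assay on RBL cells for antagonist activity at C-C chemokine receptor type 8 (Homo sapiens), read by FLIPR and calcium flux; on this read-out higher numbers stand for weaker inhibition and lower numbers for stronger inhibition. Compound 1 `COc1ccc2nccc(C3CN(C4CCN(Cc5ccccc5)CC4)C(=O)O3)c2c1` gives 12600 nM. Within the data shown here, compound 2 `COc1ccc2nccc(C3CN(C4CCN(CCCc5ccccc5)CC4)C(=O)O3)c2c1` gives 251 nM, the lowest of the two numbers; its only neighbour is compound 1, and the step of a 50-fold lower number from compound 1 to compound 2 (1.70 log units; beyond the scatter) separates them. Compound 3 `COc1ccc2nccc(C3CN(C4CCN(Cc5cccc(Cl)c5)CC4)C(=O)O3)c2c1` is not yet measured. It differs from compound 2 by 3-chlorophenyl in place of phenethyl on a saturated chain carbon bound to an amine nitrogen in a ring.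

Among the measured compounds shown here, the one measured step that bears on this change is a 50-fold lower number from compound 1 to compound 2 (1.70 log units; beyond the scatter), and the change to compound 3 runs it largely backwards: the chain on the ring amine nitrogen returns to the single carbon of compound 1, with a chlorine added to the aromatic ring. For the measured compounds named here, no measured pair shows what a chlorine on that ring does, so that part of the change is unsupported by data. The expectation is therefore a large rise in the number, a 20-fold higher number from compound 2 to compound 3 (1.30 log units; beyond the scatter), landing closer to compound 1 than to compound 2. Compound 3 is estimated at 5000 nM, with a range from 1500 nM to 20000 nM.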

Compound 3, half-maximal inhibitory concentration: 6310 nM
Estimate against measurement, compound 3: 1.3-fold (0.10 log units) below, within the range that was stated.
By their numbers in this assay, from the lowest: compound 2; then compounds 3 and 1 (each within the scatter of the next).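

In this assay, 3-chlorobenzyl in place of 3-phenylpropyl gives a 25-fold higher number from compound 2 to compound 3 (1.40 log units; beyond the scatter), so a chlorine on the aromatic ring of the one-carbon group does not recover the low number that compound 2 holds with its longer chain. Read on its own, chloro in place of hydrogen on an aromatic carbon gives a 2.0-fold lower number from compound 1 to compound 3 (0.30 log units; within the scatter), so the chlorine does not separate compound 3 from compound 1, and among these three compounds the large differences appear only where the chain on the amine nitrogen in a ring changes, with compound 2 alone standing apart from the other two. No measurement on hand accounts for either step.

The compounds shown leave open whether a chloro on the aromatic ring of the 3-phenylpropyl group would be as indifferent there as it is on the benzyl group of compound 1, or would move the number of compound 2. They also leave open whether a 2-phenylethyl or 4-phenylbutyl chain would fall on the same trend, and whether a fluoro or methoxy group on that ring would read differently from chloro.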